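A few compounds are considered here, and "the series" means these few. Any claim that something is new, unique, unknown or untested is made for them only; others in the source may bear on it.

Measured compounds:
- compound 2 `C=CNCc1cc(-c2c(C(=O)NCC)noc2-c2cc(C(C)C)c(O)cc2O)on1`: 43 nM
- compound 3 `CCNC(=O)c1noc(-c2cc(C(C)C)c(O)cc2O)c1-c1cc(C(=O)OCC)no1`: 9000 nM
- compound 1 `CCNC(=O)c1noc(-c2cc(C(C)C)c(O)cc2O)c1-c1cc(COCC(=O)OC)no1`: "not determined" (no result reported)

In a functional assay on A2780 cells (Homo sapiens) for inhibition (a lower number here means a stronger inhibitor, a higher number a weaker inhibitor), compound 2 gives the lowest of the two numbers measured; compound 3 stands a long way above it, and compound 1 has no number. Going by the values given here, the only measured step that bears on the question is a 210-fold higher number from compound 2 to compound 3 (2.32 log units; beyond the scatter), which replaced the (vinylamino)methyl group with an ethoxycarbonyl group in the same place.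

Compound 4 `CCNC(=O)c1cc(-c2c(C(=O)NCC)noc2-c2cc(C(C)C)c(O)cc2O)on1` differs from compound 2 by ethylcarbamoyl in place of (vinylamino)methyl on an aromatic carbon. Among the compounds with values here, the group that enters is not the one that entered in compound 3, but it also takes the place of the (vinylamino)methyl group on the same ring carbon, so the one measured step is the closest guide, and a large rise in the number in this assay is expected, though with wide uncertainty about its size. Compound 4 is therefore expected to give 3000 nM in this assay, with a range from 600 nM to 15000 nM. That estimate means an expected step of a 70-fold higher number from compound 2 to compound 4 (1.84 log units; beyond the scatter).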

Compound 4, half-maximal inhibitory concentration: 43 nM
Compound 4: middle estimate off by 70-fold (1.84 log units), on the high side; measured number outside the range, below it.
By their numbers in this assay, from the lowest: compounds 2 and 4 (each within the scatter of the next); then compound 3.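

In this assay, ethylcarbamoyl can take the place of (vinylamino)methyl on this aromatic carbon with no change at the digits printed from compound 2 to compound 4 (within the scatter), so a carbonyl attached at this position does not by itself bring the high number seen for compound 3. What separates compound 3 from compound 4 is the group on that carbonyl: ethylamino in place of ethoxy gives a 210-fold lower number from compound 3 to compound 4 (2.32 log units; beyond the scatter), a large difference from a change in one part of the group. Nothing measured here explains why the amide and the ester differ so widely.

From the compounds shown here alone, it remains open how much the ethyl chain on the amide matters, since a plain primary amide or a longer propyl chain could read differently. A carboxylic acid or a simple amine at this position is also untested by the compounds shown.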